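Swapping Difluoromethoxy for Dimethylamino on Compound 2

The source may report more compounds than this note shows. Statements on the series, on what has been measured and on what is new or still open speak of the compounds shown alone.

Compound 1, `COc1cc([C@](O)(CCN(C)C)[C@@H](c2cc3cc(C#N)ccc3nc2OC)c2cccc(C)c2F)cc(OC(F)F)n1`: 5.9 uL/min
Compound 2, `COc1cc([C@](O)(CCN(C)C)[C@@H](c2cc3cc(C#N)ccc3nc2OC)c2ccnc(OC)c2OC)cc(OC(F)F)n1`: 11 uL/min

In an ADME assay on microsomes from liver (Mus musculus) for metabolic stability (a lower number here means slower removal, a higher number faster removal of the compound), compound 2 gives 11 uL/min. Within the data shown here, the only measured step, a 1.9-fold higher number from compound 1 to compound 2 (0.27 log units; within the scatter), lies within the scatter, so the two measured numbers cannot be told apart. Compound 3, `COc1cc([C@](O)(CCN(C)C)[C@@H](c2cc3cc(C#N)ccc3nc2OC)c2ccnc(OC)c2OC)cc(N(C)C)n1`, has yet to be measured. It differs from compound 2 by dimethylamino in place of difluoromethoxy on an aromatic carbon. Among the measured compounds shown here, that measured step changes a different part of the molecule, so no measured step bears on this change. Accordingly no step beyond the scatter is expected for compound 3, no change at the digits printed from compound 2 to compound 3 (within the scatter). Compound 3 is estimated at 11 uL/min, in the range 4.5 uL/min to 27 uL/min.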

Compound 3, intrinsic clearance in a liver preparation (reported as CLH), per the amount of preparation that the assay uses: 16 uL/min
Beside the measured number, compound 3's estimate is 1.5-fold (0.16 log units) below it; measured number inside the range.
By their numbers in this assay, from the lowest: compounds 1, 2 and 3 (each within the scatter of the next, the first and the last beyond it).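

In this assay, dimethylamino in place of difluoromethoxy on the aromatic carbon next to the ring nitrogen gives a 1.5-fold higher number from compound 2 to compound 3 (0.16 log units; within the scatter). Among these compounds, this is the first measured change at this position, and compound 2 and compound 3 cannot be told apart here. No measurement shown explains this result.

Going by these compounds, whether a carboxylic acid or a longer chain ending in an amine at this position would give a step beyond the scatter stays open. So does whether this exchange gives a similar step with the 2-fluoro-3-methylphenyl group of compound 1.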